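Hydrogen for phenyl on compound 2

The compounds below may be only part of what the source reports. "The series", "measured", "known", "first", "only" and "open" are said of these compounds alone.

Compound 2 `O=C(/C=C/[C@H]1OCCC[C@H]1O)OCc1ccccc1` stands at > 100000 nM in a functional assay on WiDr cells (Homo sapiens) for antiproliferative activity, read by sulforhodamine B assay, with a stated time of 48 h (a higher number here means a weaker inhibitor of growth, a lower number a stronger inhibitor of growth), and this value is a limit of the assay, not a number.

Compound 1 `CC(C)(C)[Si](C)(C)O[C@@H]1CCCO[C@@H]1/C=C/C(=O)OCc1ccccc1` gives 90000 nM in this assay, and compound 3 `COC(=O)/C=C\[C@H]1OCCC[C@H]1O[Si](C)(C)C(C)(C)C` gives 38000 nM. For the measured compounds named here, the one measured step, an at least 1.1-fold higher number from compound 1 to compound 2 (0.04 log units; that floor lies within the scatter), has a floor within the scatter and lies at a different place in the structure, so it bears only indirectly.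

Compound 4 `COC(=O)/C=C/[C@H]1OCCC[C@H]1O` differs from compound 2 by hydrogen in place of phenyl on a saturated chain carbon bound to an oxygen next to a carbonyl group. Going by the values given here, no measured step covers this change.

The expected step, an at least 1.1-fold lower number from compound 2 to compound 4 (0.04 log units; that floor lies within the scatter), is none beyond the scatter. For compound 4 the estimate is 90000 nM, with an expected range of 40000 nM to 150000 nM.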

Compound 4, concentration for 50% growth inhibition: > 100000 nM
Compound 4 was reported as a limit; the forecaster's own chance of this, stated with the estimate: 60%; middle value at least 1.1-fold (0.04 log units) away from the limit.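

No step can be read from compound 2 to compound 4, since both stand only as limits in this assay: the limit of > 100000 nM in this assay, at which 2 of the 4 values shown sit.

Whether hydrogen in place of phenyl changes growth inhibition at all stays open in the compounds shown.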